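This account rests on a few compounds, and the source may have more. Where it says the series, first, only, none or still open, it means among the compounds named here.

In a functional assay on KBVIN cells (Homo sapiens) for antiproliferative activity, read by sulforhodamine B assay, with a stated time of 3 days (a higher number here means that more compound is needed for the effect, a lower number that less compound is needed), two compounds sharing one core have been measured so far. Compound 1 (`CCC1=C(O)c2c(oc(-c3ccc(Br)cc3)cc2=O)C(CC)(CC)C1=O`) gives 15.7 uM, and compound 2 (`CCC1=C(O)c2c(oc(-c3cc(C)c(O)c(C)c3)cc2=O)C(CC)(CC)C1=O`) gives 8.9 uM. Going by the values given here, compound 2 thus stands within the scatter of compound 1, the only other measured compound, so the two cannot be ranked. Compound 3 (`CCC1=C(O)c2c(oc(-c3ccc(F)c(C)c3)cc2=O)C(CC)(CC)C1=O`) has not yet been measured. It carries 4-fluoro-3-methylphenyl in place of 4-hydroxy-3,5-dimethylphenyl on an aromatic carbon, next to the ring oxygen: 4-fluoro-3-methylphenyl in place of 4-hydroxy-3,5-dimethylphenyl on an aromatic carbon. Among the compounds with values here, only one measured step bears on this change, and it falls at the same place on the core: a 1.8-fold lower number from compound 1 to compound 2 (0.25 log units; within the scatter). Within the data shown here, no measured compound carries the 4-fluoro-3-methylphenyl group, so this single step is a thin guide. On the strength of that step, which stayed within the scatter, no shift beyond the scatter is expected for compound 3. The expected change is small, an estimated 1.3-fold higher number from compound 2 to compound 3 (0.13 log units; within the scatter). For compound 3 the estimated value is 12 uM, with an expected range from 6 uM to 25 uM.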

Compound 3, concentration for half-maximal effect: 1.62 uM
Estimate against measurement, compound 3: 7.4-fold (0.87 log units) above; the whole stated range lies above it.
By their numbers in this assay, from the lowest: compound 3; then compounds 2 and 1 (each within the scatter of the next).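

At this aromatic carbon, next to the ring oxygen, the choice of aryl group can move the number in this assay beyond the scatter, which the earlier exchange of aryl groups did not show: 4-fluoro-3-methylphenyl in place of 4-hydroxy-3,5-dimethylphenyl gives a 5.5-fold lower number from compound 2 to compound 3 (0.74 log units; beyond the scatter) and in place of 4-bromophenyl gives a 9.7-fold lower number from compound 1 to compound 3 (0.99 log units; beyond the scatter). Compound 3 is thus the lowest of the three, yet the missing hydroxy group does not by itself go with a low number, since compound 1 also lacks a hydroxy group and stands within the scatter of compound 2. Nothing in the data offered here accounts for the shift, so the numbers show its size but not its origin.

The compounds shown leave open whether the low number of compound 3 goes with the fluorine, with the methyl or only with the two together. Going by these compounds, it also remains open how far this position would tolerate a larger change, such as an amine or a carboxylic acid on the phenyl ring, or a methoxy group in place of the fluorine.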